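Methoxyphenyl for methylphenyl: expectation for compound 4

A few compounds are considered here, and "the series" means these few. Any claim that something is new, unique, unknown or untested is made for them only; others in the source may bear on it.

Measured in an in vitro functional assay on cells for agonist activity at Bombesin receptor subtype-3 (Mus musculus), read by luminescence and calcium flux; on this read-out lower numbers stand for an effect already at smaller amounts and higher numbers for an effect only at larger amounts of compound:
compound 1 `CCCCc1cnc(C(CCC)Cc2ccc(-c3ccccc3C(=O)O)cc2)[nH]1` gives 165 nM
compound 2 `Cc1cccc(Cc2cnc(CCc3ccc(-c4ccccc4C(=O)O)cc3)[nH]2)c1` gives 75 nM
compound 3 `CCCCc1cnc(C(CC)Cc2ccc(-c3ccccc3C(=O)O)cc2)[nH]1` gives 340 nM

Compound 2 holds the lowest number of the three; compound 1 is its nearest neighbour, and compound 3 stands furthest from it, both gaps beyond the scatter. Among the compounds with values here, the only step between measured compounds that differ in one place is a 2.1-fold higher number from compound 1 to compound 3 (0.31 log units; beyond the scatter), which concerns the alkyl chain and not the aryl group on the saturated chain carbon bound to an aromatic carbon.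

Compound 4 `COc1ccccc1Cc1cnc(CCc2ccc(-c3ccccc3C(=O)O)cc2)[nH]1` differs from compound 2 by 2-methoxyphenyl in place of 3-methylphenyl on a saturated chain carbon bound to an aromatic carbon. Within the data shown here, no measured step bears on this aryl exchange, so the expectation rests on compound 2 alone. With the rest of the structure unchanged, a step no larger than modest in either direction is expected, with a slightly higher number the more likely outcome given the loss of the substituent pattern that gave compound 2 its low value. Compound 4 is therefore estimated at 110 nM, range 40 nM to 320 nM, an expected step of a 1.5-fold higher number from compound 2 to compound 4 (0.17 log units; within the scatter).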

Compound 4, half-maximal effective concentration: 163 nM
Beside the measured number, compound 4's estimate is 1.5-fold (0.17 log units) below it, within the range that was stated.
By their numbers in this assay, from the lowest: compound 2; then compounds 4 and 1 (each within the scatter of the next); then compound 3.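

In this assay, the exchange of 2-methoxyphenyl for 3-methylphenyl on a saturated chain carbon bound to an aromatic carbon gives a 2.2-fold higher number from compound 2 to compound 4 (0.34 log units; beyond the scatter) as the first step read at this position, so the aryl group here does affect the number, though the step is only modest. Within the data shown here, the exchange changes both the substituent and its place on the ring, and the single step cannot divide its size between the two. Nothing available gives a reason for the step.

The compounds shown leave open how 3-methoxyphenyl or 2-methylphenyl would compare with compound 2, which would separate the substituent from its place. Also open, on these data alone, is how an unsubstituted phenyl, or a ring carrying an amine or a carboxylic acid, would read at this position.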